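Working notes: from compound 3 to compound 4

A few compounds are considered here, and "the series" means these few. Any claim that something is new, unique, unknown or untested is made for them only; others in the source may bear on it.

- compound 1 `COc1cccc(OCCC(C)(C)C)c1C(=O)/C=C/c1ccc(O)cc1`: > 30000 nM
- compound 2 `O=C(/C=C/c1ccc(O)cc1)c1c(O)cccc1OCC1CCCCC1`: > 30000 nM
- compound 3 `CCCCOc1cccc(O)c1C(=O)/C=C/c1ccc(O)cc1`: > 30000 nM

In a functional assay on ACHN cells (Homo sapiens) for antiproliferative activity, read by sulforhodamine B assay (a higher number here means a weaker inhibitor of growth, a lower number a stronger inhibitor of growth), compound 3 gives > 30000 nM, which is a limit and not a number. All three compounds sit at the limit of > 30000 nM in this assay, at which 3 of the 3 values shown sit.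

Compound 4 `O=C(/C=C/c1ccc(O)cc1)c1c(O)cccc1OCCC1CCCC1` differs from compound 3 by cyclopentyl in place of ethyl on a saturated chain carbon, two bonds along the chain from an oxygen on an aromatic ring.

Going by the values given here, the only measured step that bears on this is a step that the two limits leave unreadable from compound 2 to compound 3, so no size can be carried over. No clear shift is expected in this assay. The expected change is a number no higher from compound 3 to compound 4 (the limit leaves the size open). Compound 4 is estimated at 30000 nM, with an expected range of 12000 nM to 60000 nM.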

Compound 4, concentration for 50% growth inhibition: 3400 nM
Compound 4: middle estimate off by 8.8-fold (0.95 log units), on the high side; measured number outside the range, below it.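

In this assay, the side chain on the oxygen proves able to move the read-out: butoxy to 2-cyclopentylethoxy gives an at least 8.8-fold lower number from compound 3 to compound 4 (0.94 log units; beyond the scatter). Carrying a ring is not sufficient, as compound 2 also has one, and cyclopentylmethyl in place of cyclohexyl gives an at least 8.8-fold lower number from compound 2 to compound 4 (0.94 log units; beyond the scatter). Compound 4 alone has a number, and the other values are limits, not numbers: the limit of > 30000 nM in this assay, at which 3 of the 4 values shown sit.

Both steps therefore give only a minimum size. As far as these compounds go, whether a 2-cyclohexylethoxy chain, a longer chain before the cyclopentyl ring, or an amine on the chain would keep this activity remains open.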